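The source may hold more compounds than are shown below. What is called first, only, known or untested is meant among the compounds shown, and "the series" means these compounds.

Measured compounds in a functional assay on HT-29 cells (Homo sapiens) for inhibition, read by MTT assay, with a stated time of 2 days; a higher number here means a weaker inhibitor of growth, a lower number a stronger inhibitor of growth:
- compound 1 `COc1cccc(-c2nc3c(-c4ccc(Cl)cc4)n[nH]c3c(=O)n2NC(=O)c2ccccc2)c1` gives 20400 nM
- compound 2 `O=C(Nn1c(-c2ccccc2)nc2c(-c3ccc(Cl)cc3)n[nH]c2c1=O)c1ccccc1` gives 20600 nM
- compound 3 `O=C(Nn1c(CCc2ccccc2)nc2c(-c3ccc(Cl)cc3)n[nH]c2c1=O)c1ccccc1` gives 23400 nM

Compound 3 holds the highest of the three numbers, but its nearest neighbour, compound 2, sits only a 1.1-fold higher number from compound 2 to compound 3 (0.06 log units; within the scatter) away, and compound 1, the furthest, only a 1.1-fold higher number from compound 1 to compound 3 (0.06 log units; within the scatter); neither gap is beyond the scatter, so the three compounds cannot be told apart in this assay.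

Compound 4 `CCCc1nc2c(-c3ccc(Cl)cc3)n[nH]c2c(=O)n1NC(=O)c1ccccc1` differs from compound 3 by methyl in place of phenyl on a saturated chain carbon, two bonds along the chain from an aromatic carbon. The one part of the shared core that has been varied so far is the group on this same aromatic carbon: from compound 1 to compound 3 the change was a 1.1-fold higher number from compound 1 to compound 3 (0.06 log units; within the scatter), and from compound 2 to compound 3 it was a 1.1-fold higher number from compound 2 to compound 3 (0.06 log units; within the scatter). Both exchanges, removing a methoxy-bearing or a bare phenyl ring or stretching it out on a chain, left the number where it was. The step to compound 4 is of the same kind, cutting the chain back to propyl, and on that record no movement beyond the scatter is expected, a 1.0-fold lower number from compound 3 to compound 4 (0.01 log units; within the scatter). Compound 4 is therefore estimated at 23000 nM, with a range from 11000 nM to 50000 nM.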

Compound 4, concentration for 50% growth inhibition: 9260 nM
The estimate for compound 4 lay 2.5-fold (0.40 log units) above the measured number, outside the stated range (below it).
By their numbers in this assay, from the lowest: compound 4; then compounds 1, 2 and 3 (each within the scatter of the next).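

In this assay the group on this aromatic carbon proves able to move the number after all: with phenyl on the chain exchanged for methyl, leaving propyl, the step is beyond the scatter, though modest (a 2.5-fold lower number from compound 3 to compound 4 (0.40 log units; beyond the scatter)). The ring-bearing groups, which could not be told apart from one another, all stand on the weaker side of propyl, whether the ring sits directly on this carbon as bare phenyl (a 2.2-fold lower number from compound 2 to compound 4 (0.35 log units; beyond the scatter)) or as 3-methoxyphenyl (a 2.2-fold lower number from compound 1 to compound 4 (0.34 log units; beyond the scatter)), so among these four compounds the group without a ring gives the strongest inhibitor of growth and a ring at this position is not needed for activity. Nothing at hand explains why this exchange lowers the number.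

The compounds shown leave open whether the number keeps falling with a shorter chain such as ethyl or methyl, or rises again with a longer one such as butyl, and how an amine or a carboxylic acid at the end of the chain would behave. They also leave open whether the same step would hold if the other parts of the shared core were changed.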